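From isobutyl to isopropyl: a half-life estimate for compound 3

The source may report more compounds than this note shows. Statements on the series, on what has been measured and on what is new or still open speak of the compounds shown alone.

Going by the values given here, in an ADME assay on liver (Rattus norvegicus) for metabolic stability (a higher number here means that the compound lasts longer, a lower number that the compound disappears faster), compound 2 (`CC(C)C[C@@H](N)C(=O)OC[C@H]1O[C@@H](n2cnc3c(N)ncnc32)[C@@H](O)[C@@H]1O`) stands lowest of the two compounds measured so far, at 0.06 h, while compound 1 (`CC(C)[C@@H](N)C(=O)OC[C@H]1O[C@@H](n2cnc3c(N)ncnc32)[C@@H](O)[C@@H]1O`) gives 0.46 h. Compound 3 (`CC(C)[C@H](N)C(=O)OC[C@H]1O[C@@H](n2cnc3c(N)ncnc32)[C@@H](O)[C@@H]1O`) has not yet been measured in this assay. The structural change leading to it from compound 2 is 1-amino-2-methylpropyl in place of 1-amino-3-methylbutyl on a carbonyl carbon, and it sits on a carbonyl carbon whose other neighbour is an oxygen next to a carbonyl group. Among the compounds with values here, one measured step bears on this change: a 7.7-fold lower number from compound 1 to compound 2 (0.88 log units; beyond the scatter), a drop beyond the scatter for the same exchange of groups run the other way. Read in reverse, that step points to a rise. The guide is imperfect, however. Within the data shown here, the defined stereocentre of compound 3 has the opposite arrangement to that of compound 1, and no measured compound shows what such a switch does. Only part of the measured size is therefore carried over. An upward step a 2.5-fold higher number from compound 2 to compound 3 (0.40 log units; beyond the scatter) is expected, smaller than the measured one and with wide uncertainty. For compound 3 the estimated half-life is 0.15 h, with an expected range of 0.04 h to 0.6 h.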

Compound 3, half-life: 0.03 h
For compound 3 the middle estimate is 5.0-fold (0.70 log units) above the measured one; the whole stated range lies above it.
By their numbers in this assay, from the lowest: compounds 3 and 2 (each within the scatter of the next); then compound 1.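

The result shows that at this position the arrangement at the stereocentre matters as much as the identity of the group on the carbonyl carbon. In this assay, inverting that single centre gives a 15-fold lower number from compound 1 to compound 3 (1.19 log units; beyond the scatter), a step larger than the one earlier seen on exchanging the groups, which was a 7.7-fold lower number from compound 1 to compound 2 (0.88 log units; beyond the scatter). The rise that the earlier step suggested does not appear when 1-amino-2-methylpropyl enters with the opposite arrangement, as the listed step is a 2.0-fold lower number from compound 2 to compound 3 (0.30 log units; within the scatter), so the effect of the group exchange depends on the configuration that comes with it. The large step can be assigned to the stereocentre alone, since nothing else separates the pair: the fact that compounds 1 and 3 differ only in the configuration as drawn.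

Still open, as far as these compounds go, is how 1-amino-3-methylbutyl behaves with the opposite arrangement at its stereocentre, since the exchange of groups has so far been seen cleanly with only one configuration. The compounds shown also leave open whether the same dependence on configuration holds for a longer chain or a benzyl group on this carbon, or for an amide in place of the ester oxygen.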